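Extending a fluorinated ether chain on the shared core

The source may report more compounds than this note shows. Statements on the series, on what has been measured and on what is new or still open speak of the compounds shown alone.

Compound 1 `CCCCN1CCC(COC(=O)c2ccc(NC)c3c2OCCO3)CC1` gives 9.1 nM in an assay on HEK293 cells for displacement of a labelled ligand from 5-hydroxytryptamine receptor 4 (Homo sapiens); on this read-out higher numbers stand for weaker inhibition and lower numbers for stronger inhibition.
Compound 2 `CCCN1CCC(COC(=O)c2ccc(N)c(OC)c2)CC1` gives 17 nM in this assay.
Compound 3 `CCCCN1CCC(COC(=O)c2ccc(N)c(OCF)c2)CC1` gives 17 nM in this assay.

Compound 3 stands level with compound 2 at the digits shown, and these two are together the highest of the three numbers; the gap from compound 3 down to compound 1 lies within the usual scatter, so no ranking among the three can be drawn. Compound 4 `CCCCN1CCC(COC(=O)c2ccc(N)c(OCCF)c2)CC1` has not been measured. It differs from compound 3 by fluoromethyl in place of fluoro on a saturated chain carbon bound to an oxygen on an aromatic ring. Among the compounds with values here, no pair of measured compounds shows a change of this kind, so there is no measured step to lean on. The expected step is a 1.3-fold higher number from compound 3 to compound 4 (0.11 log units; within the scatter), small and not clearly beyond the scatter. Compound 4 is therefore estimated at 22 nM, with a range from 7 nM to 65 nM.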

Compound 4, inhibition constant: 11 nM
Estimate against measurement, compound 4: 2.0-fold (0.30 log units) above; the range from low to high includes it.
By their numbers in this assay, from the lowest: compounds 1, 4, 2 and 3 (each within the scatter of the next).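

In this assay, within the data shown here, the change from fluoromethoxy to 2-fluoroethoxy reads as a 1.5-fold lower number from compound 3 to compound 4 (0.19 log units; within the scatter) and is the first measured step at this position. The chain on this oxygen can therefore take the fluoromethyl in place of fluoro without a shift beyond the scatter in either direction. Nothing at hand speaks to a cause for this result.

Still open, going by these compounds, is whether a longer chain, such as 3-fluoropropyl, would hold the same level on this oxygen. The same goes for a chain without fluorine, such as ethyl, and for trifluoromethyl.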